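Dropping One Methoxy Group: A Step Expected Within Scatter

A few compounds are considered here, and "the series" means these few. Any claim that something is new, unique, unknown or untested is made for them only; others in the source may bear on it.

Compound 1 `COc1ccc(-c2cc(/C=C/C(=O)c3ccc(N)cc3)[nH]n2)cc1` gives 1210 nM.
Compound 2 `COc1cc(-c2cc(/C=C/C(=O)c3ccc(N)cc3)[nH]n2)cc(OC)c1OC` gives 1620 nM.

Both numbers come from a functional assay on NCI-H522 cells (Homo sapiens) for inhibition, read by sulforhodamine B assay, with a stated time of 48 h; on this read-out lower numbers stand for stronger inhibition of growth and higher numbers for weaker inhibition of growth. Compound 2 gives the highest of the two numbers, but its difference from compound 1 lies within the usual scatter, so the two compounds cannot be told apart on this read-out.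

Compound 3 `COc1ccc(-c2cc(/C=C/C(=O)c3ccc(N)cc3)[nH]n2)cc1OC` has not yet been measured. It differs from compound 2 in one place: hydrogen in place of methoxy on an aromatic carbon. Going by the values given here, no pair of measured compounds isolates this single change. Compound 1 and compound 2, which differ in more than one place, already sit within the scatter of each other, so a smaller change of this kind is expected to give no step beyond the scatter in this assay, in either direction.

Compound 3 is therefore expected to give about 1400 nM, within a range from 700 nM to 2800 nM. The step this estimate implies, a 1.2-fold lower number from compound 2 to compound 3 (0.06 log units; within the scatter), is expected to stay within the scatter.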

Compound 3, concentration for 50% growth inhibition: 1650 nM
Compound 3: the middle estimate sits 1.2-fold (0.07 log units) below what was measured, within the range that was stated.
By their numbers in this assay, from the lowest: compounds 1, 2 and 3 (each within the scatter of the next).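

In this assay the methoxy group ortho to a methoxy group and meta to a large group can now be judged on its own: replacing it with hydrogen gives a 1.0-fold higher number from compound 2 to compound 3 (0.01 log units; within the scatter), so this single change produces no step beyond the scatter. Viewed from the other side, methoxy in place of hydrogen on an aromatic carbon of compound 1 gives a 1.4-fold higher number from compound 1 to compound 3 (0.13 log units; within the scatter), also within the scatter, so neither one-place change separates the compounds joined by it. No supporting measurement is available to explain these results.

Only hydrogen and methoxy are shown at this position, so it remains open whether a larger or different group, such as ethoxy, an amine or a carboxylic acid, would give a step beyond the scatter.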